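The source may hold more compounds than are shown below. What is called first, only, known or untested is meant among the compounds shown, and "the series" means these compounds.

Compound 3 `COc1nc2ccccc2cc1/C=C/c1noc(-c2cccc(C)c2)n1` stands at a limit in an ADME assay on HepG2 cells (Homo sapiens) for cytotoxicity, read by sulforhodamine B assay, with a stated time of 48 h (a lower number here means that less compound is tolerated, a higher number that more compound is tolerated), where compound 3 gives > 230000 nM. Compound 2 `COc1nc2ccccc2cc1/C=C/c1noc(-c2ccccc2C)n1` likewise reaches a limit in this assay, giving > 230000 nM. Compound 1 `COc1nc2ccccc2cc1/C=C/c1noc(-c2ccc(Br)cc2)n1` gives > 195000 nM, again a limit rather than a number. The values gather at the limit of > 230000 nM in this assay, at which 2 of the 3 values shown sit, and at the limit of > 195000 nM in this assay, at which 1 of the 3 values shown sits, so the steps a step that the two limits leave unreadable from compound 1 to compound 2, a step that the two limits leave unreadable from compound 1 to compound 3 and a step that the two limits leave unreadable from compound 2 to compound 3 cannot be read in size or direction. Compound 4 `COCc1nc(/C=C/c2cc3ccccc3nc2OC)no1` differs from compound 3 by methoxymethyl in place of 3-methylphenyl on an aromatic carbon. For the measured compounds named here, since no measured step offers a readable size, no direction is expected for the step of a number no higher from compound 3 to compound 4 (the limit leaves the size open), which is expected to stay beyond what this assay resolves. Compound 4 is therefore expected to give about 230000 nM, within a range from 100000 nM to 500000 nM.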

Compound 4, half-maximal cytotoxic concentration: > 270000 nM
Compound 4 ended at the assay's limit; the forecaster's own chance of this, stated with the estimate: 80%; middle value at least 1.1-fold (0.06 log units) from the limit.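

Compound 4 stands at a limit in this assay, as do compound 1, compound 2 and compound 3, and its steps to those three cannot be read in size or direction. The compounds shown leave open at what concentration any of them becomes cytotoxic, and whether the group exchanged on the shared core changes that at all.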